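This account rests on a few compounds, and the source may have more. Where it says the series, first, only, none or still open, it means among the compounds named here.

In an ADME assay on HEK293 cells (Homo sapiens) for cytotoxicity, read by reporter gene assay and resazurin assay, with a stated time of 48 h (on this read-out lower numbers stand for higher toxicity in this test and higher numbers for lower toxicity in this test), compound 1 `COc1ccc(Br)cc1C(=O)Nc1ccc(Sc2nc3ccccc3s2)cc1` gives > 100000 nM, which is a limit and not a number. Among the compounds with values here, compound 2 `O=C(Nc1ccc(Sc2nc3ccccc3s2)cc1)c1cccc(Br)c1` gives 74000 nM, the only actual number so far. Compound 3 `O=C(Nc1ccc(Sc2nc3ccccc3s2)cc1)c1cc(Br)ccc1O` departs from compound 2 by a single change, hydroxy in place of hydrogen on an aromatic carbon, so that 3-bromophenyl becomes 5-bromo-2-hydroxyphenyl. Within the data shown here, only one measured step bears on this, also a change on an aromatic carbon, though with methoxy rather than hydroxy: an at least 1.3-fold lower number from compound 1 to compound 2 (0.13 log units; that floor lies within the scatter). That step rests on (the limit of > 100000 nM in this assay, at which 1 of the 2 values shown sits). Among the measured compounds shown here, with only this step as a guide, and that step not beyond the scatter, no clear shift in either direction is expected in this assay. The expected change is a 1.2-fold lower number from compound 2 to compound 3 (0.09 log units; within the scatter). For compound 3 the estimate is 60000 nM, with an expected range from 20000 nM to 100000 nM.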

Compound 3, half-maximal cytotoxic concentration: 42000 nM
Estimate against measurement, compound 3: 1.4-fold (0.15 log units) above; the measured number falls inside the stated range.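

On the 5-bromo-2-hydroxyphenyl ring, hydroxy in place of hydrogen gives a 1.8-fold lower number from compound 2 to compound 3 (0.25 log units; within the scatter), so in this assay hydroxy at this place cannot be told apart from hydrogen. What matters more is what sits on the oxygen: hydrogen in place of methyl gives an at least 2.3-fold lower number from compound 1 to compound 3 (0.37 log units; beyond the scatter) and is the only step shown that lies beyond the scatter, with the lower number, and so the higher toxicity in this test, on the hydroxy side. That size is only a floor, and it rests on a limit: the limit of > 100000 nM in this assay, at which 1 of the 3 values shown sits.

From the compounds shown here alone, whether an amine or a carboxylic acid at this place, or a longer chain on the oxygen such as ethoxy, would read like hydroxy or like methoxy stays open. Also open, going by these compounds, is whether the same swap gives a similar step without the bromo group.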